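Swapping methoxy for chloro on the amide-side ring

The source may report more compounds than this note shows. Statements on the series, on what has been measured and on what is new or still open speak of the compounds shown alone.

Measured so far:
compound 1 `COc1ccc(NC(=O)CSc2nnc(-c3cc(OC)c(OC)c(OC)c3)n2-c2ccc(OC)cc2)cc1`, 25800 nM
compound 2 `COc1ccc(-n2c(SCC(=O)Nc3ccc(Cl)cc3)nnc2-c2cc(OC)c(OC)c(OC)c2)cc1`, 6290 nM
compound 3 `COc1ccc(NC(=O)CSc2nnc(-c3cc(OC)c(OC)c(OC)c3)n2-c2ccc(N(C)C)cc2)cc1`, 56100 nM

These three compounds were tested in a functional assay on PC-3 cells (Homo sapiens) for inhibition, read by MTT assay, with a stated time of 48 h; a lower number here means a stronger inhibitor, a higher number a weaker inhibitor. Compound 1 and compound 2 differ in one spot: chloro in place of methoxy on an aromatic carbon. That change gave a 4.1-fold lower number from compound 1 to compound 2 (0.61 log units; beyond the scatter).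

The cores of compound 1 and compound 3 differ elsewhere: dimethylamino in place of methoxy on an aromatic carbon. That change gave a 2.2-fold higher number from compound 1 to compound 3 (0.34 log units; beyond the scatter), so compound 3 has the highest number of the three.

Compound 4 `COc1cc(-c2nnc(SCC(=O)Nc3ccc(Cl)cc3)n2-c2ccc(N(C)C)cc2)cc(OC)c1OC` has not yet been measured. It stands to compound 3 as compound 2 stands to compound 1: chloro in place of methoxy on an aromatic carbon. The place of the change is described in the same words for both pairs, so this is the same change made on a different core.

If the change behaves on the core of compound 3 as it did on the core of compound 1, compound 4 is expected to show a 4.0-fold lower number from compound 3 to compound 4 (0.60 log units; beyond the scatter), resting on the step of a 4.1-fold lower number from compound 1 to compound 2 (0.61 log units; beyond the scatter). The estimate for compound 4 in this assay is therefore 14000 nM, expected to fall between 5000 nM and 40000 nM.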

Compound 4, half-maximal inhibitory concentration: > 60000 nM
Compound 4 ended at the assay's limit; the forecaster's own chance of this, stated with the estimate: 10%; middle value at least 4.2-fold (0.63 log units) away from the limit.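

In this assay, compound 4 gives > 60000 nM, which is a limit of the assay and not a number, so the steps to it are only floors. As far as these compounds go, their true size stays unknown. On the core of compound 3, chloro in place of methoxy gave an at least 1.0-fold higher number from compound 3 to compound 4 (0.02 log units; that floor lies within the scatter), so the drop seen on the core of compound 1 did not carry over: the same change on two cores in this assay, a 4.1-fold lower number (0.61 log units; beyond the scatter) from compound 1 to compound 2 and an at least 1.0-fold higher number (0.02 log units; that floor lies within the scatter) from compound 3 to compound 4, at least 4.3-fold (0.64 log units) apart, beyond the scatter of two such steps Read the other way, dimethylamino in place of methoxy gave an at least 9.5-fold higher number from compound 2 to compound 4 (0.97 log units; beyond the scatter), so this change also depended on the core it was made on: the same change on two cores in this assay, a 2.2-fold higher number (0.34 log units; beyond the scatter) from compound 1 to compound 3 and an at least 9.5-fold higher number (0.97 log units; beyond the scatter) from compound 2 to compound 4, at least 4.3-fold (0.64 log units) apart, beyond the scatter of two such steps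

The compounds shown leave open whether this mismatch is tied to the dimethylamino group or would also appear with another group in its place, such as a plain amine or a hydroxyl. They also leave open how a fluoro or bromo group would behave in place of chloro on either core.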